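The source may hold more compounds than are shown below. What is called first, only, known or untested is meant among the compounds shown, and "the series" means these compounds.

Measured compounds in this assay:
- Compound 1, `Cc1cccc(N2CCC(C(=O)Nc3ccc4c(c3)NC(=O)CO4)CC2)c1`: 225 nM
- Compound 2, `O=C1COc2ccc(NC(=O)C3CCN(c4cccc(Cl)c4)CC3)cc2N1`: 97 nM

In an assay on HEK293 cells for displacement of a labelled ligand from transient receptor potential cation channel subfamily V member 1 (Homo sapiens) (a lower number here means a stronger inhibitor, a higher number a weaker inhibitor), compound 2 holds the lower of the two numbers shown. Within the data shown here, its only neighbour is compound 1, and the single measured step, a 2.3-fold lower number from compound 1 to compound 2 (0.37 log units; beyond the scatter), separates them.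

Compound 3, `Cc1cccc(N2CCC(C(=O)Nc3ccc4c(c3)NC(=O)CO4)CC2)c1C`, is the next compound to be measured. It differs from compound 2 by 2,3-dimethylphenyl in place of 3-chlorophenyl on an amine nitrogen in a ring. Among the measured compounds shown here, the one step that bears on this change is a 2.3-fold lower number from compound 1 to compound 2 (0.37 log units; beyond the scatter), which ran in the opposite direction, methyl giving way to chloro; compound 3 reverses that exchange and carries a second methyl, for which no measured comparison exists. The reversal of that step leads to the expectation that the number for compound 3 rises back toward compound 1, a modest step of a 2.4-fold higher number from compound 2 to compound 3 (0.37 log units; beyond the scatter). Compound 3 is therefore estimated at 230 nM, with a range from 80 nM to 700 nM.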

Compound 3, inhibition constant: 28 nM
Estimate against measurement, compound 3: 8.2-fold (0.91 log units) above; measured number below the stated range.
By their numbers in this assay, from the lowest: compound 3; then compound 2; then compound 1.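

In this assay, the earlier pair compared only methyl with chloro at one place on the aromatic ring, whereas compound 3 shows what a second substituent on that ring does: methyl in place of hydrogen on an aromatic carbon gives an 8.0-fold lower number from compound 1 to compound 3 (0.91 log units; beyond the scatter). The exchange of 3-chlorophenyl for 2,3-dimethylphenyl on the amine nitrogen in the ring gives a 3.5-fold lower number from compound 2 to compound 3 (0.54 log units; beyond the scatter), so the advantage of chloro over methyl seen in a 2.3-fold lower number from compound 1 to compound 2 (0.37 log units; beyond the scatter) does not decide the order here, and compound 3, with no chlorine, holds the lowest number of the three. Nothing available explains why the added methyl has this effect.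

The compounds shown leave open whether the added methyl acts alone or only together with the first methyl. They also leave open whether a chloro, fluoro or methoxy group in its place would give a similar number.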